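The compounds below may be only part of what the source reports. "The series", "measured", "known", "first", "only" and "open" are said of these compounds alone.

Measured so far in a functional assay on the whole organism for inhibition, with Rattus norvegicus as the target, with stated times of 1 h and 3.5 h, at a dose of 100 mg/kg by the oral route; on this read-out higher numbers stand for more inhibition at the one dose given (going by the name of the read-out) and lower numbers for less inhibition:
compound 1, `CC(C)(C)c1nc(N)ncc1-c1ccccc1`: 46%
compound 2, `CC(=O)N(C(C)=O)c1ncc(-c2ccccc2)c(C(C)(C)C)n1`: 22%

Compound 2 stands lowest of the two numbers in this assay. Within the data shown here, the only other number is that of compound 1, and the single measured step, a number 24 percentage points lower from compound 1 to compound 2 (beyond the scatter), lies beyond the scatter. That step put diacetylamino in place of amino on an aromatic carbon of the shared core.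

Compound 3, `CC(C)(C)c1nc(NN)ncc1-c1ccccc1`, has not yet been measured. It differs from compound 2 as follows: aminoamino in place of diacetylamino on an aromatic carbon. The step from compound 1 to compound 2 bears directly on this change, since it is the same position and the diacetylamino that lowered the number is now removed again; the entering aminoamino, like the amino of compound 1, carries hydrogen-bond donors where diacetylamino carried none. Among the measured compounds shown here, a rise of roughly the same size as that step, back toward the level of compound 1, is therefore expected, although only one step supports this and aminoamino itself has no precedent.

Compound 3 is estimated at 40% in this assay, with a range of 20% to 60%; the expected step is a number 18 percentage points higher from compound 2 to compound 3 (beyond the scatter).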

Compound 3, a percentage reported as inhibition, in the whole organism at one dose (the size of the read-out at that dose, not a potency): < 5%
Compound 3: a limit, no number; the forecaster's own chance of this, stated with the estimate: 0%; at least 35 percentage points between middle value and limit.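

In this assay compound 3 stands at a limit of the assay and not at a number: the limit of < 5% in this assay, at which 1 of the 3 values shown sits. Amino in place of hydrogen on a nitrogen on an aromatic ring gives a number at least 41 percentage points lower from compound 1 to compound 3 (beyond the scatter), and aminoamino in place of diacetylamino gives a number at least 17 percentage points lower from compound 2 to compound 3 (beyond the scatter). Removing diacetylamino from this aromatic carbon, between two ring nitrogen atoms, therefore does not by itself restore the number of compound 1, and among the three groups shown here amino alone goes with the highest number, while the added amino of aminoamino takes the read-out lower than diacetylamino did.

On these data alone, what separates amino from aminoamino stays open, since the three compounds cannot tell whether a small substituent on this nitrogen in general goes with the loss or only a second amino does, and methylamino, dimethylamino, acetylamino or a hydroxyl group at this place would address that. As far as these compounds go, the tert-butyl and phenyl groups are the same throughout, so it is also open whether the order of these groups holds with, for instance, a cyclohexyl group in place of phenyl.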